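The source may hold more compounds than are shown below. What is called first, only, known or untested is meant among the compounds shown, and "the series" means these compounds.

Of the compounds shown here, two have so far been measured in an assay on isolated protein for activation of Nicotinamide phosphoribosyltransferase (Homo sapiens); a lower number here means that less compound is needed, a higher number that more compound is needed for the effect. Compound 1 `O=C(NCc1ccncc1)Nc1ccc(S(=O)(=O)c2ccccc2)cc1` gives 85 nM in this assay. Compound 2 `CCOC(=O)c1ccc(NC(=O)NCc2cn[nH]c2)cc1`, built on a different core, gives 1850 nM in this assay; this is the higher of the two numbers, and the gap between the two compounds lies beyond the usual scatter of repeated measurements. Compound 3 `CCOC(=O)c1ccc(NC(=O)NCc2c[nH]nn2)cc1` has not yet been measured. It keeps the core of compound 2 and alters only the small aromatic ring at its end: 1H-1,2,3-triazol-4-yl in place of 1H-pyrazol-4-yl on a saturated chain carbon bound to an amide-type nitrogen. For the measured compounds named here, no measured pair shows this exact exchange, so its effect cannot be read from the data; the ring stays five-membered and aromatic, with nitrogen taking the place of carbon. Nothing measured here speaks for a large shift in either direction. The step from compound 2 to compound 3 in this assay is therefore expected to be a 1.2-fold higher number from compound 2 to compound 3 (0.08 log units; within the scatter), a change that would not stand out from the scatter. Compound 3 is expected to give 2200 nM in this assay, with a plausible range from 800 nM to 6000 nM.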

Compound 3, half-maximal effective concentration: 7750 nM
Compound 3: middle estimate off by 3.5-fold (0.55 log units), on the low side; the measured number lies above the stated range.
By their numbers in this assay, from the lowest: compound 1; then compound 2; then compound 3.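

For the compounds shown here, compound 2 and compound 3 differ in one place only, so this pair gives the first direct reading of the small aromatic ring on a saturated chain carbon bound to an amide-type nitrogen in this assay: 1H-1,2,3-triazol-4-yl in place of 1H-pyrazol-4-yl gives a 4.2-fold higher number from compound 2 to compound 3 (0.62 log units; beyond the scatter). Going by these compounds alone, the ring stays five-membered and aromatic, with the same number of heavy atoms and hydrogen-bond donors, and only one ring carbon gives way to nitrogen, with one more hydrogen-bond acceptor counted, so even an exchange this small can move the number at this position. Nothing available accounts for the size or direction of this step.

This single pair cannot show whether the same exchange would move the number in the same direction on the core of compound 1, or whether another ring with a different count of nitrogens would follow the same trend. It also leaves open how a simple amine or a carboxylic acid at this position, in place of the aromatic ring, would compare with 1H-pyrazol-4-yl.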